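The source may hold more compounds than are shown below. What is called first, only, known or untested is meant among the compounds shown, and "the series" means these compounds.

Compound 1 `O=C(Nc1ccc(Cl)cc1)NS(=O)(=O)c1cccs1` gives 16% in a functional assay on the whole organism (6C3HED cells, Mus musculus) for inhibition, at a dose of 150 mg/kg by the oral route; on this read-out lower numbers stand for less inhibition and higher numbers for more inhibition at the one dose given (going by the name of the read-out). Compound 2 `CCc1ccc(S(=O)(=O)NC(=O)Nc2ccc(Cl)cc2)s1` gives 57%. Compound 3 `O=C(Nc1ccc(Cl)cc1)NS(=O)(=O)c1cc(Br)c(Br)s1` gives 25%.

On these three numbers compound 3 sits between the other two: one of its steps is a number 9 percentage points higher from compound 1 to compound 3 (within the scatter), and the other is a number 32 percentage points lower from compound 2 to compound 3 (beyond the scatter). The untested compound 4 `Cc1cc(S(=O)(=O)NC(=O)Nc2ccc(Cl)cc2)sc1C` differs from compound 3 in one place: 4,5-dimethylthiophen-2-yl in place of 4,5-dibromothiophen-2-yl on a sulfonyl sulfur.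

For the measured compounds named here, two measured steps bear on this change. The step of a number 41 percentage points higher from compound 1 to compound 2 (beyond the scatter) shows that an alkyl group on the thiophene ring goes with a large rise in inhibition, and the step of a number 32 percentage points lower from compound 2 to compound 3 (beyond the scatter) shows that exchanging that alkyl group for the two bromines brings a large fall. Compound 4 carries two methyl groups in place of the bromines, so the move from compound 3 toward compound 4 resembles a reversal of the step from compound 2 to compound 3, and an increase beyond the scatter in this assay is expected. Going by these compounds, whether two methyl groups behave like one ethyl group is unknown from these three compounds, so the range is kept wide. Compound 4 is expected to give about 45% in this assay, between 22% and 68%, an expected step of a number 20 percentage points higher from compound 3 to compound 4 (beyond the scatter).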

Compound 4, a percentage reported as inhibition, in the whole organism at one dose (the size of the read-out at that dose, not a potency): 42%
The estimate for compound 4 lay 3 percentage points above the measured number; measured number inside the range.
By their numbers in this assay, from the lowest: compounds 1 and 3 (each within the scatter of the next); then compound 4; then compound 2.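

On the sulfonyl sulfur, the change from 4,5-dibromothiophen-2-yl to 4,5-dimethylthiophen-2-yl, with the same count of heavy atoms on each side, gives a number 17 percentage points higher from compound 3 to compound 4 (beyond the scatter) in this assay and shows that the two disubstituted thiophene groups do not read alike, whereas compound 1 and compound 3 stand within the scatter of each other. The 4,5-dimethylthiophen-2-yl group also gives a number 26 percentage points higher from compound 1 to compound 4 (beyond the scatter) against the plain thiophen-2-yl group, yet the comparison with 5-ethylthiophen-2-yl gives a number 15 percentage points lower from compound 2 to compound 4 (beyond the scatter) and so separates the two alkyl patterns, and among these four compounds both alkyl-bearing groups give higher numbers than the plain and dibromo groups, with no compound going against this. Nothing at hand explains these differences.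

The four compounds leave open whether the number depends on the length of the alkyl chain or on how many alkyl groups the ring carries, and the two alkyl patterns differ in both respects at once. They also leave open how a longer chain such as propyl or butyl, or an amine or a carboxylic acid on the thiophene ring, would read at this position.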